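The source may report more compounds than this note shows. Statements on the series, on what has been measured and on what is new or still open speak of the compounds shown alone.

Three compounds sharing one core open this series in a functional assay on MCF7 cells (Homo sapiens) for cytotoxicity, read by MTT assay, with a stated time of 72 h; a lower number here means a stronger inhibitor, a higher number a weaker inhibitor. Compound 1 (`CNC(=O)c1cc(Oc2ccc(C(=O)/C=C/c3ccc(Br)cc3)cc2)ccn1`) gives > 50000 nM, which is a limit of the assay and not a number. For compound 2 (`CNC(=O)c1cc(Oc2ccc(C(=O)/C=C/c3ccc([N+](=O)[O-])cc3)cc2)ccn1`) the entry reads "not determined" (no result reported). For the measured compounds named here, compound 3 (`CNC(=O)c1cc(Oc2ccc(C(=O)/C=C/c3ccc(C#N)cc3)cc2)ccn1`) gives 9520 nM, the only actual number among the three.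

Compound 4 (`CNC(=O)c1cc(Oc2ccc(C(=O)/C=C/c3ccc(Cl)cc3Cl)cc2)ccn1`) is the next to be read in this assay. Its change from compound 3 is 2,4-dichlorophenyl in place of 4-cyanophenyl on a double-bonded chain carbon bound to a double-bonded chain carbon. Going by the values given here, one measured step bears on this change, namely an at least 5.2-fold lower number from compound 1 to compound 3 (0.72 log units; beyond the scatter), where cyano takes the place of bromo on an aromatic carbon. Going from compound 3 to compound 4 also gives up the cyano group for halogen, so that step is expected to run partly in reverse, toward a higher number and a weaker inhibitor. Among the compounds with values here, no measured compound carries the 2,4-dichlorophenyl group, and the expectation rests on that single step. The expected change is a 2.5-fold higher number from compound 3 to compound 4 (0.40 log units; beyond the scatter), a modest one, and it may end at the limit of the assay. For compound 4 the estimated value is 24000 nM, with an expected range from 7000 nM to 50000 nM.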

Compound 4, half-maximal inhibitory concentration: 3990 nM
Compound 4: the middle estimate sits 6.0-fold (0.78 log units) above what was measured; the measured number lies below the stated range.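

In this assay, replacing the nitrile-bearing ring with a halogen-bearing one did not cost activity, unlike what the earlier bromo-to-cyano step suggested: 2,4-dichlorophenyl in place of 4-cyanophenyl on a double-bonded chain carbon bound to a double-bonded chain carbon gave a stronger inhibitor (a 2.4-fold lower number from compound 3 to compound 4 (0.38 log units; beyond the scatter)). So at this place the presence of halogen does not by itself mark the weaker compound, since the two halogen-bearing compounds stand well apart (an at least 12-fold lower number from compound 1 to compound 4 (1.09 log units; beyond the scatter)). Compound 1 gives > 50000 nM as a limit of the assay and not a number, so the size of that gap is known only from one side: the limit of > 50000 nM in this assay, at which 1 of the 4 values shown sits.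

The compounds shown do not separate what each of the two chlorine atoms of the 2,4-dichlorophenyl group contributes, and a phenyl ring carrying a single chlorine would be needed to do that. On these data alone, whether a methoxy or dimethylamino group on this ring would extend the trend or break it also remains open.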